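The source may report more compounds than this note shows. Statements on the series, on what has been measured and on what is new or still open speak of the compounds shown alone.

Values in a functional assay on HCT-116 cells (Homo sapiens) for inhibition, read by sulforhodamine B assay, with a stated time of 48 h, tested at 50 uM (on this read-out higher numbers stand for more inhibition of growth at the one concentration tested and lower numbers for less inhibition of growth), so far:
compound 1 `COc1cccc(/C=C/C(=O)/C=C/c2ccc(OCc3cn(CCCCOc4cc(=O)oc5ccccc45)nn3)c(OC)c2)c1` gives 44%
compound 2 `COc1cc(/C=C/C(=O)/C=C/c2ccccc2)ccc1OCc1cn(CCCCOc2cc(=O)oc3ccccc23)nn1` gives 34%
compound 3 `COc1ccccc1/C=C/C(=O)/C=C/c1ccc(OCc2cn(CCCCOc3cc(=O)oc4ccccc34)nn2)c(OC)c1` gives 43%

No order can be read among these values, and compound 3 stands level with the other two within the scatter. The steps that place it are a number 1 percentage points lower from compound 1 to compound 3 (within the scatter) and a number 9 percentage points higher from compound 2 to compound 3 (within the scatter) and neither leaves the scatter.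

Next is compound 4 `COc1ccc(/C=C/C(=O)/C=C/c2ccc(OCc3cn(CCCCOc4cc(=O)oc5ccccc45)nn3)c(OC)c2)cc1` with the change 4-methoxyphenyl in place of 2-methoxyphenyl on a double-bonded chain carbon bound to a double-bonded chain carbon in which 4-methoxyphenyl takes the place of 2-methoxyphenyl on a double-bonded chain carbon bound to a double-bonded chain carbon.

Among the compounds with values here, the closest precedent is 2-methoxyphenyl in place of 3-methoxyphenyl at that same place, which gave a number 1 percentage points lower from compound 1 to compound 3 (within the scatter) and so showed no measurable shift. The other change in the set, hydrogen in place of methoxy on an aromatic carbon, gave a number 10 percentage points lower from compound 1 to compound 2 (within the scatter) and also stays within the scatter. Within the data shown here, none of the measured compounds carries the 4-methoxyphenyl group, so the evidence is indirect.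

No step beyond the scatter is expected in this assay and no direction is favoured. The expected step is a number 1 percentage points lower from compound 3 to compound 4 (within the scatter) and it should remain small. Compound 4 is estimated at 42% with an expected range from 31% to 53% for the measurement.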

Compound 4, percent growth inhibition at one concentration: 40%
For compound 4 the middle estimate is 2 percentage points above the measured one; measured number inside the range.
By their numbers in this assay, from the lowest: compounds 2, 4, 3 and 1 (each within the scatter of the next).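

In this assay the methoxy group has now been read in all three placements on the phenyl ring at this chain carbon. With 4-methoxyphenyl in place of 2-methoxyphenyl the result is a number 3 percentage points lower from compound 3 to compound 4 (within the scatter) and with 4-methoxyphenyl in place of 3-methoxyphenyl it is a number 4 percentage points lower from compound 1 to compound 4 (within the scatter), so the three methoxyphenyl compounds stand level and the placement of the methoxy shows no measurable effect on this read-out. The comparison with the compound lacking this methoxy, a number 6 percentage points higher from compound 2 to compound 4 (within the scatter), also stays inside the scatter, and no evidence bears on why these values lie so close together.

Still open, going by these compounds, is whether a different group on this phenyl ring, such as an amine or a carboxylic acid, or a longer chain in place of the methoxy, would move the value beyond the scatter. With each compound read at a single concentration, the four also remain without any comparison across a range of concentrations.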